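Anilino series: removing the methoxy group

A few compounds are considered here, and "the series" means these few. Any claim that something is new, unique, unknown or untested is made for them only; others in the source may bear on it.

Compound 3 `COc1cccc(NC2=CC(=O)c3nc4n(c3C2=O)[C@H]2OC[C@@H](O)[C@H]2OC4)c1` stands among three measured values that all lie within the scatter of one another: in a functional assay on HeLa cells (Homo sapiens) for inhibition, read by sulforhodamine B assay (on this read-out lower numbers stand for stronger inhibition and higher numbers for weaker inhibition), compound 3 gives 4280 nM. Compound 1 `O=C1C=C(Nc2ccc(I)cc2)C(=O)c2c1nc1n2[C@H]2OC[C@@H](O)[C@H]2OC1` gives 4070 nM in this assay, and compound 2 `Cc1ccc(NC2=CC(=O)c3nc4n(c3C2=O)[C@H]2OC[C@@H](O)[C@H]2OC4)cc1` gives 3860 nM. The three steps between them, a 1.1-fold lower number from compound 1 to compound 2 (0.02 log units; within the scatter), a 1.1-fold higher number from compound 1 to compound 3 (0.02 log units; within the scatter) and a 1.1-fold higher number from compound 2 to compound 3 (0.04 log units; within the scatter), show that exchanging iodo for methyl on the aromatic carbon, or swapping 4-iodophenyl or 4-methylphenyl for 3-methoxyphenyl on the amine nitrogen, leaves the read-out unchanged within the scatter.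

Compound 4 `O=C1C=C(Nc2ccccc2)C(=O)c2c1nc1n2[C@H]2OC[C@@H](O)[C@H]2OC1` is the unsubstituted anilino member. The change from compound 3 is hydrogen in place of methoxy on an aromatic carbon. Within the data shown here, no measured step removes a substituent outright; the nearest precedents are the three exchanges among aryl substituents, every one within the scatter. Since iodo, methyl and methoxy are indistinguishable in this assay, the aryl substituent does not appear to steer the number within this set, and the expected step of a 1.0-fold lower number from compound 3 to compound 4 (0.01 log units; within the scatter) is none beyond the scatter. Compound 4 is therefore estimated at 4200 nM, with a range from 2400 nM to 7500 nM; the range is set wider than the measured spread to allow for the absence of any precedent for removing a group.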

Compound 4, half-maximal inhibitory concentration: 5620 nM
Beside the measured number, compound 4's estimate is 1.3-fold (0.13 log units) below it; the range from low to high includes it.
By their numbers in this assay, from the lowest: compounds 2, 1, 3 and 4 (each within the scatter of the next).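

Removing the aryl substituent outright gives a 1.3-fold higher number from compound 3 to compound 4 (0.12 log units; within the scatter), a 1.5-fold higher number from compound 2 to compound 4 (0.16 log units; within the scatter) and a 1.4-fold higher number from compound 1 to compound 4 (0.14 log units; within the scatter) in this assay, so hydrogen joins methoxy, methyl and iodo as a group that cannot be told apart on this read-out. The earlier compounds covered only exchanges of one substituent for another, whereas compound 4 shows that, among these four compounds, a substituent on the phenyl ring of the anilino group is not needed to keep the number within the scatter of the substituted members. No accompanying data bear on the reason for this flat result.

It remains open whether a carboxylic acid, a dimethylamino group or a longer alkoxy chain on the phenyl ring would also stay within the scatter, since the groups shown are limited to iodo, methyl, methoxy and hydrogen. Also open, from the compounds shown here alone, is whether the read-out would hold if a benzyl group or a pyridine ring took the place of the phenyl ring on the amine nitrogen.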